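The compounds below may be only part of what the source reports. "The series", "measured", "known", "first", "only" and "open" are said of these compounds alone.

Compound 1 `C=C1C(=O)O[C@H]2[C@H]1CC/C(COC(=O)CCC(=O)N1CCN(C(=O)Cn3cc(F)c(=O)[nH]c3=O)CC1)=C\CC[C@@]1(C)O[C@@H]21` in a functional assay on Bel-7402 cells (Homo sapiens) for antiproliferative activity, read by MTT assay, with a stated time of 72 h (a lower number here means a stronger inhibitor, a higher number a weaker inhibitor), gives only a limit, > 20000 nM. Compound 2 `C=C1C(=O)O[C@H]2[C@H]1CC/C(COC(=O)CCC(=O)N1CCN(C(=O)Cn3cc(F)c(=O)n(Cc4ccccc4)c3=O)CC1)=C\CC[C@@]1(C)O[C@@H]21` likewise returns only a limit in this assay, > 20000 nM. Between the two, a step that the two limits leave unreadable from compound 1 to compound 2, so that pair yields no readable size. For the measured compounds named here, compound 3 `C=C1C(=O)O[C@H]2[C@H]1CC/C(COC(=O)Cn1cc(F)c(=O)n(Cc3ccc(C(F)(F)F)cc3)c1=O)=C\CC[C@@]1(C)O[C@@H]21` in this assay gives 2250 nM, the only number in the set; the other two values sit at the limit of > 20000 nM in this assay, at which 2 of the 3 values shown sit. The change to compound 4 `C=C1C(=O)O[C@H]2[C@H]1CC/C(COC(=O)Cn1cc(F)c(=O)n(CCC)c1=O)=C\CC[C@@]1(C)O[C@@H]21` is ethyl in place of 4-(trifluoromethyl)phenyl on a saturated chain carbon bound to an aromatic nitrogen. Going by the values given here, no measured step alters that same place, and the single one-point step is unreadable, so there is no basis for expecting a size or direction beyond the scatter. Compound 4 is therefore expected at 4000 nM in this assay, within 1500 nM to 15000 nM. The step of a 1.8-fold higher number from compound 3 to compound 4 (0.25 log units; within the scatter) is an estimate anchored only on compound 3.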

Compound 4, half-maximal inhibitory concentration: 8580 nM
Compound 4: middle estimate off by 2.1-fold (0.33 log units), on the low side; the measured number falls inside the stated range.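

Ethyl in place of 4-(trifluoromethyl)phenyl, on a saturated chain carbon bound to an aromatic nitrogen, gives a 3.8-fold higher number from compound 3 to compound 4 (0.58 log units; beyond the scatter) in this assay. For the compounds shown here, this place therefore responds to the change, and this is the first step with a readable size, since the one earlier step cannot be read. Nothing given here accounts for the step.

Going by these compounds, whether the step follows the aromatic ring or the trifluoromethyl stays open. On these data alone, how a plain benzyl, a longer alkyl chain or a chain ending in an amine would read at this place on the core of compound 3 also stays open.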